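The source may report more compounds than this note shows. Statements on the series, on what has been measured and on what is new or still open speak of the compounds shown alone.

Measured so far:
- Compound 1 `c1cncc(CN(CCCCN(C[C@H]2Cc3ccccc3CN2)[C@H]2CCCc3cccnc32)Cc2cccnc2)c1` gives > 30000 nM in a functional assay on cells for agonist activity at C-X-C chemokine receptor type 4 (Homo sapiens), read by fluorescence and calcium flux, with a stated time of 90 s; a lower number here means that less compound is needed, a higher number that more compound is needed for the effect.
- Compound 2 `c1ccc2c(c1)CN[C@@H](CN(CCCCNCC1CCNCC1)[C@H]1CCCc3cccnc31)C2` gives > 30000 nM in this assay.

Neither of these is a number in the usual sense. The value of compound 2 is a limit of the assay, not a measured concentration. The same holds for compound 1. Compound 2 therefore stands at the limit of > 30000 nM in this assay, at which 2 of the 2 values shown sit, and nothing separates it from compound 1 on the evidence shown.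

Compound 3 `O=S1(=O)CCC(NCCCCN(C[C@H]2Cc3ccccc3CN2)[C@H]2CCCc3cccnc32)CC1` has not yet been measured in this assay. It differs from compound 2 in a single place: 1,1-dioxothian-4-yl in place of (piperidin-4-yl)methyl on an amine nitrogen.

For the measured compounds named here, no step between two measured compounds is available to size this change. Because both measured values sit at the limit of > 30000 nM in this assay, at which 2 of the 2 values shown sit, the expectation for compound 3 is a step that the limit leaves unreadable from compound 2 to compound 3, which is none beyond the usual scatter. For compound 3 the estimated value is 50000 nM, expected to fall between 20000 nM and 200000 nM, most likely reported once more as a limit.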

Compound 3, half-maximal effective concentration: > 30000 nM
Compound 3 gave a limit, no number; the forecaster's own chance of this, stated with the estimate: 85%; the middle value is on the limit's open side.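

No step can be read between compound 2 and compound 3, since both values are limits and not numbers: the limit of > 30000 nM in this assay, at which 3 of the 3 values shown sit.

The compounds shown leave open whether 1,1-dioxothian-4-yl and (piperidin-4-yl)methyl differ at all in this assay, and which change to the shared core would give a measurable value.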